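A Methyl Group at a New Place on Compound 1

The source may hold more compounds than are shown below. What is called first, only, known or untested is meant among the compounds shown, and "the series" means these compounds.

Among the compounds with values here, in a functional assay on cells (Tumor Cell line, Homo sapiens) for antiproliferative activity (on this read-out lower numbers stand for stronger inhibition of growth and higher numbers for weaker inhibition of growth), compound 1 (`Oc1cc(-c2ccc3ccccc3c2)nc2ncccc12`) gives 8130 nM, the higher of the two numbers measured so far. Compound 2 (`Cc1ccnc2nc(-c3ccc4ccccc4c3)cc(O)c12`) gives 1200 nM. Within the data shown here, the only measured step is a 6.8-fold lower number from compound 1 to compound 2 (0.83 log units; beyond the scatter), and it comes from putting a methyl in place of a hydrogen on an aromatic carbon.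

Compound 3 (`Cc1cnc2nc(-c3ccc4ccccc4c3)cc(O)c2c1`) makes the same kind of swap at a different carbon: methyl in place of hydrogen on an aromatic carbon. Its methyl stands on an aromatic carbon of a six-membered aromatic ring with 1 nitrogen, two atoms from the ring nitrogen.

A single step is thin evidence, and the data do not show whether its size carries over to another carbon. The guide remains a 6.8-fold lower number from compound 1 to compound 2 (0.83 log units; beyond the scatter), so a smaller step in the same direction, toward a lower number in this assay, seems the cautious expectation. The expected change is a 2.9-fold lower number from compound 1 to compound 3 (0.46 log units; beyond the scatter), and a result close to compound 1 would not be surprising. For compound 3, the estimated value is 2800 nM, with an expected range from 800 nM to 9000 nM.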

Compound 3, concentration for 50% growth inhibition: 741 nM
Estimate against measurement, compound 3: 3.8-fold (0.58 log units) above, outside the stated range (below it).
By their numbers in this assay, from the lowest: compounds 3 and 2 (each within the scatter of the next); then compound 1.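

In this assay, the methyl on this second carbon, two atoms from the ring nitrogen, gives an 11-fold lower number from compound 1 to compound 3 (1.04 log units; beyond the scatter) and so shows that the earlier drop in the number was not confined to a single carbon of this ring. Compound 2 at 1200 nM and compound 3 at 741 nM lie within the usual scatter of each other, so these numbers do not separate the two places, and a methyl on either carbon goes with a number beyond the scatter of that of compound 1. The data offer no explanation for the effect of the methyl at either place.

From the compounds shown here alone, what remains open is whether this carbon accepts only a group as small as methyl, or whether an ethyl, a methoxy, an amine or a chlorine would also go with a lower number than that of compound 1. It is also unknown whether methyl groups on both carbons together would take the number lower still, or whether the two changes would simply overlap.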